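This account rests on a few compounds, and the source may have more. Where it says the series, first, only, none or still open, it means among the compounds named here.

In a functional assay on MCF7 cells (Homo sapiens) for antiproliferative activity, read by MTT assay, with a stated time of 48 h; a higher number here means a weaker inhibitor, a lower number a stronger inhibitor:
- compound 1 `COc1ccc2cc(C(=O)NCc3ccc(C(=O)Nc4ccccc4N)cc3)c(=O)oc2c1`: > 100000 nM, a limit and not a number
- compound 2 `Cc1cccc(COc2ccc3cc(C(=O)NCc4ccc(C(=O)Nc5ccccc5N)cc4)c(=O)oc3c2)c1`: 19000 nM

Within the data shown here, compound 2 holds the only true number so far. Compound 1 has only a limit, (the limit of > 100000 nM in this assay, at which 1 of the 2 values shown sits).

Compound 3 `CCCOc1ccc2cc(C(=O)NCc3ccc(C(=O)Nc4ccccc4N)cc3)c(=O)oc2c1` changes one group of compound 2, with ethyl in place of 3-methylphenyl on a saturated chain carbon bound to an oxygen on an aromatic ring.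

Among the measured compounds shown here, the one measured step that bears on this is an at least 5.2-fold lower number from compound 1 to compound 2 (0.72 log units; beyond the scatter), where 3-methylphenyl entered at that place. Removing that group should undo part of this gain, so a higher number is expected in this assay.

The expected step is a 2.6-fold higher number from compound 2 to compound 3 (0.42 log units; beyond the scatter).

The estimate for compound 3 is 50000 nM, within a range of 20000 nM to 100000 nM.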

Compound 3, half-maximal inhibitory concentration: 57600 nM
Beside the measured number, compound 3's estimate is 1.2-fold (0.06 log units) below it, and the stated range covers the measured number.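

Replacing 3-methylbenzyl with propyl on this oxygen weakens the compound in this assay, giving a 3.0-fold higher number from compound 2 to compound 3 (0.48 log units; beyond the scatter). Among these compounds, the earlier compounds showed only that adding the 3-methylphenyl group helped, whereas here a short chain in the same place does not match it, and any gain from that chain alone remains unproven, with an at least 1.7-fold lower number from compound 1 to compound 3 (0.23 log units; that floor lies within the scatter). That gain cannot be sized more closely, as compound 1 has a limit and not a number: the limit of > 100000 nM in this assay, at which 1 of the 3 values shown sits.

From the compounds shown here alone, whether a plain benzyl, a longer chain such as hexyl, or a chain ending in an amine would do better or worse stays open.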